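The compounds below may be only part of what the source reports. "The series", "measured", "known", "first", "only" and "open" are said of these compounds alone.

In a functional assay on A2780 cells (Homo sapiens) for inhibition, read by sulforhodamine B assay, with a stated time of 72 h (on this read-out higher numbers stand for weaker inhibition and lower numbers for stronger inhibition), compound 1 `O=C(NCc1ccc(S(=O)(=O)c2ccccc2)cc1)c1ccc2nccn2c1` gives 13 nM. Compound 2 `O=C(NCc1ccc(S(=O)(=O)c2ccccc2)cc1)c1cn2ccnc2cn1` gives > 10000 nM, which is a limit of the assay and not a number. For the measured compounds named here, compound 3 `O=C(NCc1ccc(S(=O)(=O)c2cccc(C(F)(F)F)c2)cc1)c1cnc2nccn2c1` has the lowest number so far, at 2 nM. Compound 4 `O=C(NCc1ccc(S(=O)(=O)c2ccccc2)cc1)c1cnc2nccn2c1` differs from compound 3 by hydrogen in place of trifluoromethyl on an aromatic carbon, with hydrogen in place of trifluoromethyl on an aromatic carbon. Going by the values given here, the only measured step, an at least 760-fold higher number from compound 1 to compound 2 (2.88 log units; beyond the scatter), changes the core, so it does not measure this swap directly. Compound 1 also lacks the trifluoromethyl and, on a different core, gives 13 nM, so a modestly higher number is expected. The estimated step is a 3.0-fold higher number from compound 3 to compound 4 (0.48 log units; beyond the scatter). Compound 4 is expected at 6 nM, within an estimated range of 2 nM to 20 nM.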

Compound 4, half-maximal inhibitory concentration: 68 nM
The estimate for compound 4 lay 11-fold (1.05 log units) below the measured number, outside the stated range (above it).
By their numbers in this assay, from the lowest: compound 3; then compound 1; then compound 4. At a limit, above all of these: compound 2.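

In this assay, for the compounds shown here, the change from 3-(trifluoromethyl)phenyl to phenyl gives a 34-fold higher number from compound 3 to compound 4 (1.53 log units; beyond the scatter) and is the first direct reading of this swap. With phenyl kept, changing the core alone gives a 5.2-fold higher number from compound 1 to compound 4 (0.72 log units; beyond the scatter) and so a smaller step. A further core change gives an at least 140-fold lower number from compound 2 to compound 4 (2.16 log units; beyond the scatter) but one end of that step is a limit of the assay and not a number: the limit of > 10000 nM in this assay, at which 1 of the 4 values shown sits.

On these data alone, whether a chlorine atom or a methoxy group in place of the trifluoromethyl would keep the number low stays open. So does the size of the same swap on the core of compound 1.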